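A few compounds are considered here, and "the series" means these few. Any claim that something is new, unique, unknown or untested is made for them only; others in the source may bear on it.

Compound 1 `Oc1ccc(-c2cc(-c3cccc(Cl)c3)nc(-c3ccccn3)c2)cc1`: 25400 nM
Compound 2 `Oc1ccc(-c2cc(-c3cccc(Cl)c3)nc(-c3cccs3)c2)cc1`: 2720 nM

For the measured compounds named here, in an ADME assay on HEK293 cells (Homo sapiens) for cytotoxicity, read by CCK-8 assay and cell counting, with a stated time of 2 days (a lower number here means a stronger inhibitor, a higher number a weaker inhibitor), compound 2 has the lower of the two numbers so far; its nearest neighbour is compound 1, and the step of a 9.3-fold lower number from compound 1 to compound 2 (0.97 log units; beyond the scatter) separates them, a change that exchanged the pyridin-2-yl ring for a thiophen-2-yl ring on the shared core. Compound 3 `Oc1ccc(-c2cc(-c3cccnc3)nc(-c3cccc(Cl)c3)c2)cc1` takes the step from compound 2 one ring further: pyridin-3-yl in place of thiophen-2-yl on an aromatic carbon. Going by the values given here, only one measured step bears on this change, and it runs the other way round, from a six-membered nitrogen ring to the five-membered sulfur ring, with a number that fell by a 9.3-fold lower number from compound 1 to compound 2 (0.97 log units; beyond the scatter). Compound 3 restores a six-membered nitrogen ring, though with the nitrogen placed differently from that of compound 1, so the step back is expected to be partial rather than a full return. Compound 3 is therefore expected to give a higher number than compound 2 in this assay, by roughly a 3.3-fold higher number from compound 2 to compound 3 (0.52 log units; beyond the scatter), and its estimated value is 9000 nM, within a range from 3000 nM to 27000 nM.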

Compound 3, half-maximal inhibitory concentration: 25700 nM
Estimate against measurement, compound 3: 2.9-fold (0.46 log units) below; the range from low to high includes it.
By their numbers in this assay, from the lowest: compound 2; then compounds 1 and 3 (each within the scatter of the next).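

Compound 3 shows that the low number of compound 2 does not carry over to a six-membered nitrogen ring at this position, next to the ring nitrogen of the shared core: in this assay the exchange of thiophen-2-yl for pyridin-3-yl gives a 9.4-fold higher number from compound 2 to compound 3 (0.98 log units; beyond the scatter), a step as large as the one first seen in the opposite direction. The placing of the nitrogen in the incoming ring makes no difference that can be read, since the exchange of pyridin-2-yl for pyridin-3-yl gives a 1.0-fold higher number from compound 1 to compound 3 (0.01 log units; within the scatter), so that among these three compounds the thiophen-2-yl ring alone stands apart from both pyridine rings. Nothing available here accounts for this separation.

With a single sulfur ring on one side and two pyridine rings on the other, the compounds shown leave open whether the lower number follows the five-membered ring, the sulfur atom or the absence of a ring nitrogen. Going by these compounds, a furan-2-yl ring, a plain phenyl ring or a pyridin-4-yl ring at this position would bear on that question, and the effect of an amine or a carboxylic acid on the incoming ring remains equally open.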